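This account rests on a few compounds, and the source may have more. Where it says the series, first, only, none or still open, it means among the compounds named here.

Measured so far in a physicochemical assay for lipophilicity, at pH 7.4; a lower number here means a more polar compound, a higher number a more lipophilic compound:
- Compound 1 `CCn1nc(CC(=O)Nc2ccc(OC(F)(F)F)c(Cl)c2)c2ccccc2c1=O` gives 5.42
- Compound 2 `COc1ccc(Cl)cc1NC(=O)Cc1nn(CC(=O)O)c(=O)c2ccccc12` gives 1.9
- Compound 3 `CC(C(=O)O)c1nn(Cc2cn3cc(OCC4CC4)c(Cl)cc3n2)c2ccccc2c1=O` gives 2.44

Of these three numbers, compound 3 holds the middle place: at 2.44 it lies above compound 2 and below compound 1, with both gaps beyond the scatter.

Compound 4 `O=C(O)Cc1nn(Cc2cn3cc(OCC4CC4)c(Cl)cc3n2)c2ccccc2c1=O` has not yet been measured. It differs from compound 3 in one place (hydrogen in place of methyl on a saturated chain carbon bound to an aromatic carbon and a carbonyl carbon): hydrogen in place of methyl on a saturated chain carbon bound to an aromatic carbon and a carbonyl carbon, so that 1-carboxyethyl becomes carboxymethyl.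

Within the data shown here, no two measured compounds differ in only one place, so the data offer no measured step in this assay as a guide. Starting from compound 3 at 2.44 with the methyl gone and no net charge added, a small downward step is expected, near the edge of the scatter. The estimate is a step of a number 0.34 log units lower from compound 3 to compound 4 (beyond the scatter) on this reasoning. The estimated value for compound 4 is 2.1 with an expected range from 1.7 to 2.5 around it.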

Compound 4, distribution coefficient: 2.13
Estimate against measurement, compound 4: 0.03 log units below; the range from low to high includes it.
By their numbers in this assay, from the lowest: compounds 2 and 4 (each within the scatter of the next); then compound 3; then compound 1.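

Among these compounds, this is the first measured step in this assay between compounds that differ in only one place: replacing 1-carboxyethyl with carboxymethyl gives a number 0.31 log units lower from compound 3 to compound 4 (beyond the scatter) and leaves the rest of the structure unchanged. It shows that a single methyl on this saturated chain carbon, bound to an aromatic carbon and a carbonyl carbon, can shift the reading by a modest amount that lies beyond the usual scatter. Nothing available explains the size of this step.

On these data alone, whether an ethyl group, a second methyl or an amine on this carbon would move the number further, or in the other direction, remains open. So does whether adding a methyl to the matching carbon of compound 2 would give a similar step.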